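Extending the side chain of a labdane-type lactone inhibitor

The source may hold more compounds than are shown below. What is called first, only, known or untested is meant among the compounds shown, and "the series" means these compounds.

Measured compounds:
- compound 1, `C=C1CC[C@@H]2[C@](C)(CO)[C@H](O)CC[C@@]2(C)[C@@H]1/C=C/C1=C/C(=C/CCC)OC1=O`: 110000 nM
- compound 2, `C=C1CC[C@@H]2[C@](C)(CO)[C@H](O)CC[C@@]2(C)[C@@H]1/C=C/C1=C/C(=C/c2ccc(OC)cc2)OC1=O`: 16000 nM

Both compounds were tested in an assay on isolated protein for inhibition of Maltase-glucoamylase (Homo sapiens); on this read-out lower numbers stand for stronger inhibition and higher numbers for weaker inhibition. For the measured compounds named here, compound 2 gives the lower of the two numbers; its only neighbour is compound 1, and the step of a 6.9-fold lower number from compound 1 to compound 2 (0.84 log units; beyond the scatter) separates them.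

Compound 3, `C=C1CC[C@@H]2[C@](C)(CO)[C@H](O)CC[C@@]2(C)[C@@H]1/C=C/C1=C/C(=C/C=C/c2ccccc2)OC1=O`, has not yet been measured. It differs from compound 2 in one place: 2-phenylethenyl in place of 4-methoxyphenyl on a double-bonded chain carbon bound to a double-bonded ring carbon. Going by the values given here, the one step available, from propyl to an aromatic ring, was the modest 6.9-fold lower number from compound 1 to compound 2 (0.84 log units; beyond the scatter). The new change keeps an aromatic ring and only alters how it is attached, so the expected step of a 1.1-fold lower number from compound 2 to compound 3 (0.03 log units; within the scatter) is small and may well lie within the scatter, in no firm direction. Compound 3 is therefore estimated at 15000 nM, with a range from 5000 nM to 50000 nM.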

Compound 3, half-maximal inhibitory concentration: 58000 nM
Estimate against measurement, compound 3: 3.9-fold (0.59 log units) below, outside the stated range (above it).
By their numbers in this assay, from the lowest: compound 2; then compounds 3 and 1 (each within the scatter of the next).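

Keeping an aromatic ring at this position does not by itself preserve the result for compound 2: replacing 4-methoxyphenyl with 2-phenylethenyl gives a 3.6-fold higher number from compound 2 to compound 3 (0.56 log units; beyond the scatter), a step larger than the usual scatter. Set against the propyl group, 2-phenylethenyl gives a 1.9-fold lower number from compound 1 to compound 3 (0.28 log units; within the scatter), so these two groups cannot be told apart here, and the presence of an aromatic ring alone does not separate a compound from the propyl one. No supporting data bear on why the values fall this way.

This single change alters how the ring is attached and also removes the methoxy group, so the compounds shown leave open which of the two accounts for the step. On these data alone, how a plain phenyl group, or a phenyl ring carrying an amine, would stand at this place also remains open.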